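This account rests on a few compounds, and the source may have more. Where it says the series, first, only, none or still open, it means among the compounds named here.

Working notes on the urea series in a functional assay on NCI-H520 cells (Homo sapiens) for inhibition, read by MTT assay, with a stated time of 48 h, tested at 10 uM; on this read-out higher numbers stand for more inhibition at the one concentration tested (going by the name of the read-out) and lower numbers for less inhibition. Of the compounds shown here, three carry a number so far. Compound 1 `CCc1ccc(Nc2cc(NC(=O)Nc3c(Cl)cccc3Cl)ncn2)cc1` gives 31.5% in this assay, and it stands highest of the three, though within the scatter of both neighbours. Compound 2 `CCc1cccc(Nc2cc(NC(=O)Nc3cc(OC)cc(OC)c3)ncn2)c1` gives 23% in this assay. Compound 3 `COc1cc(NC(=O)Nc2cc(Nc3ccc(C)c(F)c3)ncn2)cc(OC)c1` gives 30.6% in this assay, a number within the scatter of compound 1.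

Within the data shown here, the one step measured so far that changes the aryl group on the amino nitrogen is a number 7.6 percentage points higher from compound 2 to compound 3 (within the scatter), a change of substituent pattern on that ring that moved nothing beyond the scatter.

The next compound, compound 4 `O=C(Nc1cc(Nc2ccc(F)c(Cl)c2)ncn1)Nc1c(Cl)cccc1Cl`, differs from compound 1 in the same place: 3-chloro-4-fluorophenyl in place of 4-ethylphenyl on a nitrogen on an aromatic ring. The change is again a swap of one aryl substituent pattern for another on the amino nitrogen, with the rest of the molecule kept. Among the measured compounds shown here, the only comparable step, the one from compound 2 to compound 3, stayed within the scatter, so no step beyond the scatter is expected here either, in either direction.

Compound 4 is therefore estimated at 31% in this assay, with a range from 15% to 47%, which means an expected step of a number 0.5 percentage points lower from compound 1 to compound 4 (within the scatter).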

Compound 4, a percentage reported as inhibition, at one concentration (the size of the read-out at that concentration, not a potency): 39.5%
Estimate against measurement, compound 4: 8.5 percentage points below; the range from low to high includes it.
By their numbers in this assay, from the lowest: compounds 2, 3, 1 and 4 (each within the scatter of the next, the first and the last beyond it).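

In this assay the new result is a number 8 percentage points higher from compound 1 to compound 4 (within the scatter), so a second exchange of the aryl group on the amino nitrogen, now made with the other urea aryl group of compound 1 in place of the dimethoxyphenyl group of the earlier pair, also stays within the scatter. The exchange replaces 4-ethylphenyl with 3-chloro-4-fluorophenyl, two groups of 8 heavy atoms, and shows that this position accepts a ring bearing chlorine and fluorine in place of one bearing an ethyl group with no change beyond the scatter, although a single step of this size sets no direction. No available evidence bears on the reason for this result.

Still open, on these data alone, is whether a basic amine such as a dimethylamino group, a carboxylic acid, or a longer chain such as hexyl on this aryl ring would produce a step beyond the scatter. The effect of the other urea aryl group alone also remains unresolved, as no pair shown differs only in that place.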